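Chloro for hydrogen on the benzylsulfanyl arm

The source may report more compounds than this note shows. Statements on the series, on what has been measured and on what is new or still open speak of the compounds shown alone.

In a functional assay on the whole organism (artery, strain albino) with Rattus norvegicus as the target, with a stated time of 300 min, at a dose of 10 mg/kg by the oral route (a lower number here means less inhibition, a higher number more inhibition at the dose given (going by the name of the read-out)), compound 1 `COc1ccc(C2N=C(SCc3ccc(F)cc3)NC(C)=C2C(=O)Nc2ccc(F)cc2)cc1OC` gives 37.9% and compound 2 `CC1=C(C(=O)Nc2ccc([N+](=O)[O-])cc2)C(c2ccc(Br)cc2)N=C(SCc2ccccc2)N1` gives 29.7%; the two numbers lie within the scatter of each other, so no order between them can be read. Compound 3 `CC1=C(C(=O)Nc2ccc([N+](=O)[O-])cc2)C(c2ccc(Br)cc2)N=C(SCc2ccccc2Cl)N1` differs from compound 2 by chloro in place of hydrogen on an aromatic carbon. Among the compounds with values here, no measured pair shows this change, so the expected step of a number 2.3 percentage points higher from compound 2 to compound 3 (within the scatter) is small, in neither direction beyond the scatter. Compound 3 is therefore estimated at 32%, with a range from 18% to 48%.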

Compound 3, a percentage reported as inhibition, in the whole organism at one dose (the size of the read-out at that dose, not a potency): 16.9%
For compound 3 the middle estimate is 15.1 percentage points above the measured one; the whole stated range lies above it.
By their numbers in this assay, from the lowest: compound 3; then compounds 2 and 1 (each within the scatter of the next).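

In this assay, within the data shown here, the change from benzylsulfanyl to (2-chlorobenzyl)sulfanyl gives a number 12.8 percentage points lower from compound 2 to compound 3 (beyond the scatter) in the first comparison here where only one place differs. It shows that this arm is not indifferent to substitution: a single chloro group on its aromatic ring is enough to lower the inhibition seen at this dose. Nothing available accounts for the step.

On these data alone, this rests on one pair, so it remains open whether a hydroxyl group or an amine at this carbon would lower the number too. As far as these compounds go, whether fluoro would do the same on this arm of compound 2 is also open.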